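A few compounds are considered here, and "the series" means these few. Any claim that something is new, unique, unknown or untested is made for them only; others in the source may bear on it.

In a physicochemical assay for solubility (a lower number here means a less soluble compound, a higher number a more soluble compound), compound 3 (`CNC(=O)c1cc(C(=O)NCCC2CCOCC2)cn(Cc2ccccc2)c1=O`) gives >= 127 ug/mL as a limit and not a number. Compound 1 (`CNC(=O)c1cc(C(=O)NCCCC2CNCCO2)cn(Cc2ccccc2)c1=O`) gives >= 194 ug/mL as a limit too. Compound 2 (`CNC(=O)c1cc(C(=O)NC2CCOCC2)cn(Cc2ccccc2)c1=O`) likewise gives >= 174 ug/mL as a limit. Compound 4 (`CNC(=O)c1cc(C(=O)NCC(C)C)cn(Cc2ccccc2)c1=O`) carries isopropyl in place of (oxan-4-yl)methyl on a saturated chain carbon bound to an amide-type nitrogen. The measured changes that bear on this side chain are a step that the two limits leave unreadable from compound 2 to compound 3 and a step that the two limits leave unreadable from compound 1 to compound 3 and neither gives a size to build on. With no readable size to carry over, no step beyond the scatter is expected in this assay and the expected step is a step that the limit leaves unreadable from compound 3 to compound 4 on that basis. For compound 4 the estimate is 140 ug/mL with an expected range from 60 ug/mL to 170 ug/mL in this measurement.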

Compound 4, solubility: 43 ug/mL
Estimate against measurement, compound 4: 3.3-fold (0.51 log units) above, and the stated range ends above it.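

In this assay, for the compounds shown here, replacing the ring-bearing side chains of the earlier compounds with the ringless isobutyl gives the first readable change at this amide-type nitrogen: an at least 2.9-fold lower number from compound 3 to compound 4 (0.47 log units; beyond the scatter), an at least 4.0-fold lower number from compound 2 to compound 4 (0.60 log units; beyond the scatter) and an at least 4.5-fold lower number from compound 1 to compound 4 (0.65 log units; beyond the scatter). The steps among compound 1, compound 2 and compound 3 cannot be read, as all three values are limits. The step from compound 3 gives only a minimum size because the value of compound 3 is a limit: the limit of >= 127 ug/mL in this assay, at which 1 of the 4 values shown sits.

Going by these compounds, the true size of each drop stays open, as does whether the ring itself or its oxygen counts. A cyclohexyl group on the same nitrogen would separate those two.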